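This account rests on a few compounds, and the source may have more. Where it says the series, first, only, none or still open, it means among the compounds named here.

Compound 1 `Oc1cccc(-c2cc(-c3ccc(OC(F)(F)F)cc3)cc(-c3ccccc3O)n2)c1` gives 21100 nM in a functional assay on DU-145 cells (Homo sapiens) for inhibition; on this read-out lower numbers stand for stronger inhibition and higher numbers for weaker inhibition. Compound 2 `Oc1ccc(-c2cc(-c3ccc(OC(F)(F)F)cc3)cc(-c3ccccc3O)n2)cc1` gives > 50000 nM in this assay, which is a limit of the assay and not a number. Compound 3 `Oc1cccc(-c2cc(-c3ccc(OC(F)(F)F)cc3)cc(-c3cccc(O)c3)n2)c1` gives > 50000 nM in this assay, again a limit and not a number.

The change from compound 1 to compound 2 is 4-hydroxyphenyl in place of 3-hydroxyphenyl on an aromatic carbon. This change produced an at least 2.3-fold higher number from compound 1 to compound 2 (0.37 log units; beyond the scatter). The two cores differ as described by 3-hydroxyphenyl in place of 2-hydroxyphenyl on an aromatic carbon, and that change produced an at least 2.3-fold higher number from compound 1 to compound 3 (0.37 log units; beyond the scatter). Both of these steps end at the limit of > 50000 nM in this assay, at which 2 of the 3 values shown sit, so neither can be sized beyond its lower bound.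

Compound 4 `Oc1ccc(-c2cc(-c3ccc(OC(F)(F)F)cc3)cc(-c3cccc(O)c3)n2)cc1` has not been measured in this assay. It differs from compound 3 by 4-hydroxyphenyl in place of 3-hydroxyphenyl on an aromatic carbon. Within the data shown here, this is the same kind of change as the one from compound 1 to compound 2, but not the same: in the earlier case the entering group sits meta to a 2-hydroxyphenyl group, whereas here it sits meta to a 3-hydroxyphenyl group. Among the measured compounds shown here, the expectation for compound 4 rests on two observations: compound 3 already sits at the limit with > 50000 nM, and the one measured instance of this kind of change gave an at least 2.3-fold higher number from compound 1 to compound 2 (0.37 log units; beyond the scatter). Compound 4 is therefore expected to remain at or beyond the limit, with an estimated value of 90000 nM, most likely between 40000 nM and 300000 nM. The step implied by this estimate is expected to be a step that the limit leaves unreadable from compound 3 to compound 4.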

Compound 4, half-maximal inhibitory concentration: 18100 nM
Beside the measured number, compound 4's estimate is 5.0-fold (0.70 log units) above it; the whole stated range lies above it.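

In this assay, the new step, an at least 2.7-fold lower number from compound 3 to compound 4 (0.44 log units; beyond the scatter), runs opposite to the earlier result for 4-hydroxyphenyl in place of 3-hydroxyphenyl, so this change does not carry from one core to the other: the same change on two cores in this assay, an at least 2.3-fold higher number (0.37 log units; beyond the scatter) from compound 1 to compound 2 and an at least 2.7-fold lower number (0.44 log units; beyond the scatter) from compound 3 to compound 4, at least 6.5-fold (0.81 log units) apart, beyond the scatter of two such steps

The same reversal appears for 3-hydroxyphenyl in place of 2-hydroxyphenyl, where the new step is an at least 2.7-fold lower number from compound 2 to compound 4 (0.44 log units; beyond the scatter), so that change does not carry across cores either: the same change on two cores in this assay, an at least 2.3-fold higher number (0.37 log units; beyond the scatter) from compound 1 to compound 3 and an at least 2.7-fold lower number (0.44 log units; beyond the scatter) from compound 2 to compound 4, at least 6.5-fold (0.81 log units) apart, beyond the scatter of two such steps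

The remaining step, a 1.2-fold lower number from compound 1 to compound 4 (0.07 log units; within the scatter), leaves the two ends of this set of compounds indistinguishable, while the steps that reach the limit give only lower bounds on their size, and two pairs of cores give no rule for any other core in the series: the limit of > 50000 nM in this assay, at which 2 of the 4 values shown sit.

The compounds shown leave open whether the dependence on the placement of the hydroxyl groups would persist if a methoxy group or an amine took the place of a hydroxyl group. They also leave open whether it would survive replacing the trifluoromethoxy group with a chlorine atom or a methyl group, since every compound here carries the same trifluoromethoxy group.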